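The source may report more compounds than this note shows. Statements on the series, on what has been measured and on what is new or still open speak of the compounds shown alone.

Working notes on the series, read in a functional assay on HeLa S3 cells (Homo sapiens) for cytotoxicity, read by XTT assay, with a stated time of 3 days; a lower number here means a stronger inhibitor, a higher number a weaker inhibitor. Compound 1 `OC[C@H]1O[C@@H](n2cc(F)c3c(-c4ccco4)ncnc32)[C@H](O)[C@@H]1O` gives 8000 nM, compound 2 `OC[C@H]1O[C@@H](n2cc(F)c3c(-c4cccs4)ncnc32)[C@H](O)[C@@H]1O` gives 4300 nM and compound 3 `OC[C@H]1O[C@@H](n2cc(F)c3c(-c4ccc[nH]4)ncnc32)[C@H](O)[C@@H]1O` gives 230 nM. Compound 3 has the lowest number of the three, and its steps to both others lie beyond the scatter.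

Compound 4 `OC[C@H]1O[C@@H](n2cc(F)c3c(-c4cc[nH]c4)ncnc32)[C@H](O)[C@@H]1O` carries 1H-pyrrol-3-yl in place of 1H-pyrrol-2-yl on an aromatic carbon.

Going by the values given here, three measured steps bear on this change, all of them swaps of the ring itself. The step of a 1.9-fold lower number from compound 1 to compound 2 (0.27 log units; within the scatter) stays within the scatter, while a 35-fold lower number from compound 1 to compound 3 (1.54 log units; beyond the scatter) and a 19-fold lower number from compound 2 to compound 3 (1.27 log units; beyond the scatter) are both large. Among the compounds with values here, no measured pair isolates a move of the attachment point, so the evidence is indirect. Within the data shown here, the low number so far belongs only to compound 3 at 230 nM, so part of that gain is expected to be lost, though probably not all of it.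

The step expected in this assay is a 2.2-fold higher number from compound 3 to compound 4 (0.34 log units; beyond the scatter), a moderate move towards a higher number. For compound 4 the estimated value is 500 nM, with an expected range of 120 nM to 2500 nM.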

Compound 4, half-maximal inhibitory concentration: 8900 nM
The estimate for compound 4 lay 18-fold (1.25 log units) below the measured number; the whole stated range lies below it.
By their numbers in this assay, from the lowest: compound 3; then compounds 2, 1 and 4 (each within the scatter of the next, the first and the last beyond it).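

In this assay the move from 1H-pyrrol-2-yl to 1H-pyrrol-3-yl keeps the same atoms and the same counts, yet gives a 39-fold higher number from compound 3 to compound 4 (1.59 log units; beyond the scatter) at this position on the carbon next to the ring nitrogen, so the low number of compound 3 depends on the attachment point and not on the presence of a pyrrole ring alone. The 1H-pyrrol-3-yl group keeps none of the gain over the other rings, with a 1.1-fold higher number from compound 1 to compound 4 (0.05 log units; within the scatter) within the scatter and a 2.1-fold higher number from compound 2 to compound 4 (0.32 log units; beyond the scatter) as a modest step towards a higher number. Nothing at hand accounts for the gap between the two pyrrole attachments.

From the compounds shown here alone, it remains open whether a methyl group on the pyrrole nitrogen would retain the low number of compound 3 at 230 nM in this series. Going by these compounds, the effect of an amine or a carboxylic acid on the 1H-pyrrol-2-yl ring also remains open.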